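Cyclopropyl for methyl at the aryl ether of compound 2

A few compounds are considered here, and "the series" means these few. Any claim that something is new, unique, unknown or untested is made for them only; others in the source may bear on it.

Measured compounds and their clearance numbers:
compound 1 `Cc1ccc([C@@H](C)Oc2cc3onc(CCC(=O)O)c3cc2Cl)nc1` gives 1.1 mL/min/kg
compound 2 `CCOc1cc2oc(=O)n(CCC(=O)O)c2cc1Cl` gives 16 mL/min/kg
compound 3 `Cc1ccc([C@@H](C)Oc2cc3onc(CCC(=O)O)c3cc2Cl)nn1` gives 12 mL/min/kg

In an ADME assay on the whole organism (blood, strain Han-Wistar) for pharmacokinetics, with Rattus norvegicus as the target, read by LC-MS, at a dose of 1 mg/kg by the intravenous route (a lower number here means slower removal, a higher number faster removal of the compound), compound 2 stands highest of the three numbers. Its nearest neighbour is compound 3, which lies within the scatter of it, while compound 1 sits far below both. Going by the values given here, the only step measured between two compounds that differ in one place is an 11-fold higher number from compound 1 to compound 3 (1.04 log units; beyond the scatter), a change of the aromatic group on the saturated chain carbon bound to the oxygen on the aromatic ring. Compound 4 `O=C(O)CCn1c(=O)oc2cc(OCC3CC3)c(Cl)cc21` is not yet measured. It differs from compound 2 by cyclopropyl in place of methyl on a saturated chain carbon bound to an oxygen on an aromatic ring. The change sits on the same kind of carbon as the step from compound 1 to compound 3, but it exchanges a small saturated group for another rather than one aromatic group for another, so that step gives no direct guide. With nothing closer to rest on, a step within the scatter is expected in this assay, in either direction. Compound 4 is therefore expected to give about 18 mL/min/kg, with a range from 8 mL/min/kg to 40 mL/min/kg, which amounts to an expected step of a 1.1-fold higher number from compound 2 to compound 4 (0.05 log units; within the scatter).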

Compound 4, clearance in the Rattus norvegicus assay: 4.1 mL/min/kg
The estimate for compound 4 lay 4.4-fold (0.64 log units) above the measured number; measured number outside the range, below it.
By their numbers in the Rattus norvegicus assay, from the lowest: compound 1; then compound 4; then compounds 3 and 2 (each within the scatter of the next).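

In the Rattus norvegicus assay, the earlier compounds had shown only that exchanging one aromatic group for another on this kind of carbon moves the number, whereas cyclopropyl in place of methyl gives a 3.9-fold lower number from compound 2 to compound 4 (0.59 log units; beyond the scatter), so a small saturated group here matters too. In a physicochemical assay for pharmacokinetics, at pH 6 (a lower number here means that the compound disappears faster, a higher number that the compound lasts longer), compound 2 gives > 1000 h, which is a limit of the assay. In the physicochemical assay, compound 4 gives > 1000 h, which is also a limit.

The step between these two compounds in the physicochemical assay cannot be read, and no comparison can be drawn from these values: the limit of > 1000 h in the physicochemical assay, at which 2 of the 2 values shown sit. The compounds shown leave open whether a cyclobutyl group, a longer chain or a phenyl group in the same place would follow cyclopropyl in the Rattus norvegicus assay, and whether this exchange would give a similar step on another core.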